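Changing the group on the carbonyl carbon

This account rests on a few compounds, and the source may have more. Where it says the series, first, only, none or still open, it means among the compounds named here.

Of the compounds shown here, three built on one shared core have been measured in an ADME assay on stomach for solubility, in simulated gastric fluid; on this read-out higher numbers stand for higher solubility and lower numbers for lower solubility. Compound 1 `O=C(Nc1ccc(OC(F)(F)F)cc1)N1CCOC2(CCN(C(=O)c3cc(Cl)ccn3)CC2)C1` gives 90 ug/mL. Compound 3 `O=C1Cc2cc(C(=O)N3CCC4(CC3)CN(C(=O)Nc3ccc(OC(F)(F)F)cc3)CCO4)ccc2N1` gives 96 ug/mL, and the step of a 1.1-fold higher number from compound 1 to compound 3 (0.03 log units; within the scatter) shows that exchanging the group on the carbonyl carbon left the number essentially unchanged. Compound 2 `O=C(Nc1ccc(C(F)(F)F)cc1)N1CCOC2(CCN(C(=O)c3c(F)cccc3F)CC2)C1` gives 43 ug/mL, the lowest of the three numbers; compound 1 lies above it by a gap beyond the scatter, and compound 3 lies further above still.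

Compound 4 `O=C(Nc1ccc(C(F)(F)F)cc1)N1CCOC2(CCN(C(=O)c3cccc(Cl)c3)CC2)C1` has not yet been measured. It differs from compound 2 in a single place: 3-chlorophenyl in place of 2,6-difluorophenyl on a carbonyl carbon. For the measured compounds named here, the only measured step that touches the same spot, the group on the carbonyl carbon, is a 1.1-fold higher number from compound 1 to compound 3 (0.03 log units; within the scatter), which stayed within the scatter even though the groups exchanged there differed more from each other than the two here do. With nothing measured that points to a sizeable shift for a change of this kind at this position, the step of a 1.0-fold higher number from compound 2 to compound 4 (0.02 log units; within the scatter) is expected to stay within the scatter. The estimated value for compound 4 in this assay is 45 ug/mL, with a range from 20 ug/mL to 100 ug/mL.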

Compound 4, solubility: 26 ug/mL
Compound 4: middle estimate off by 1.7-fold (0.24 log units), on the high side; low and high end bracket the measured number.
By their numbers in this assay, from the lowest: compounds 4 and 2 (each within the scatter of the next); then compounds 1 and 3 (each within the scatter of the next).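

In this assay, the step of a 1.7-fold lower number from compound 2 to compound 4 (0.22 log units; within the scatter) is a second exchange at the group on the carbonyl carbon that stays within the scatter, and it comes from a different setting than a 1.1-fold higher number from compound 1 to compound 3 (0.03 log units; within the scatter). That earlier step swapped one ring type for another on the core of compound 1, whereas here the six-membered aromatic ring of carbon only stays and two fluorine atoms give way to one chlorine atom at new places on it, so across these two pairs no exchange at this position has yet given a difference beyond the scatter. Why the number for compound 4 sits where it does cannot be explained, as no supporting measurement beyond these numbers bears on this result.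

The compounds shown leave open whether a group of another kind on the carbonyl carbon, such as a phenyl ring carrying an amine or a carboxylic acid, would give a step beyond the scatter. They also leave open whether 3-chlorophenyl in place of 2,6-difluorophenyl would give a similar step on a core carrying trifluoromethoxy instead of trifluoromethyl.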